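Distal aryl variation on the shared core: estimating compound 4

This account rests on a few compounds, and the source may have more. Where it says the series, first, only, none or still open, it means among the compounds named here.

Measured in an in vitro assay on CHO cells for displacement of a labelled ligand from Bombesin receptor subtype-3 (Homo sapiens), read by scintillation counting, with a stated time of 2 h; on this read-out higher numbers stand for weaker inhibition and lower numbers for stronger inhibition:
- compound 1 `CCC(C)(C)Cc1c[nH]c(CCc2ccc(-c3ccncc3)cc2)n1`: 101 nM
- compound 2 `CCC(C)(C)Cc1c[nH]c(CCc2ccc(-n3ncnn3)cc2)n1`: 205 nM
- compound 3 `CCC(C)(C)Cc1c[nH]c(CCc2ccc(-c3ccc(F)cn3)cc2)n1`: 19 nM

Compound 3 gives the lowest number of the three. Its nearest neighbour is compound 1, with a 5.3-fold lower number from compound 1 to compound 3 (0.73 log units; beyond the scatter); the gap to compound 2 is wider, an 11-fold lower number from compound 2 to compound 3 (1.03 log units; beyond the scatter). The remaining measured step, a 2.0-fold higher number from compound 1 to compound 2 (0.31 log units; beyond the scatter), is modest.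

Compound 4 `CCC(C)(C)Cc1c[nH]c(CCc2ccc(-c3cccc(N)n3)cc2)n1` differs from compound 3 in one place: 6-aminopyridin-2-yl in place of 5-fluoropyridin-2-yl on an aromatic carbon. Among the compounds with values here, none of the measured steps touches a substituent on an attached pyridin-2-yl; each swaps the whole attached ring. They do show that the pyridin-2-yl arrangement carries the lowest number in this assay, and compound 4 keeps that arrangement while the substituent on it changes. Within the data shown here, the expectation is therefore a small step in this assay, most likely toward a somewhat higher number, of a size that may sit within the scatter, with a wide range because no measured pair probes this substituent change directly. For compound 4 the estimate is 40 nM, range 12 nM to 130 nM, corresponding to an expected step of a 2.1-fold higher number from compound 3 to compound 4 (0.32 log units; beyond the scatter).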

Compound 4, half-maximal inhibitory concentration: 7.3 nM
Compound 4: middle estimate off by 5.5-fold (0.74 log units), on the high side, outside the stated range (below it).
By their numbers in this assay, from the lowest: compound 4; then compound 3; then compound 1; then compound 2.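

6-Aminopyridin-2-yl in place of 5-fluoropyridin-2-yl gives, in this assay, a 2.6-fold lower number from compound 3 to compound 4 (0.42 log units; beyond the scatter), the first evidence that changing only the substituent on the attached pyridin-2-yl moves the number beyond the scatter, and here it moves it lower. Compound 4 now stands lowest of the four, and the steps from the other attached rings widen to a 14-fold lower number from compound 1 to compound 4 (1.14 log units; beyond the scatter) and a 28-fold lower number from compound 2 to compound 4 (1.45 log units; beyond the scatter), so the pyridin-2-yl arrangement is not the only contributor to the low numbers. Nothing shown accounts for the drop.

The change swaps both the substituent and its place on the ring, so the two effects remain unseparated; a 5-aminopyridin-2-yl or a 6-fluoropyridin-2-yl group would divide them. On these data alone, whether the free amine itself matters also stays open, and a 6-(methylamino)pyridin-2-yl group would address that.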